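Adding a tert-butyl group to a phenoxypropanamide acid

The compounds below may be only part of what the source reports. "The series", "measured", "known", "first", "only" and "open" are said of these compounds alone.

Compound 1, with the structure `CC(Oc1ccccc1)C(=O)Nc1ccc(OCC(=O)O)c(F)c1`, is an amide bearing a phenoxy-substituted chain on one side and, on the other, a fluorinated ring that carries an oxyacetic acid group. In a physicochemical assay for lipophilicity, using the shake flask method, at pH 7.4 (a higher number here means a more lipophilic compound, a lower number a more polar compound), compound 1 gives -0.18. Two close relatives were made as well: compound 2, `CC(C)(Oc1ccccc1)C(=O)Nc1ccc(OCC(=O)O)c(F)c1`, with a second methyl on the carbon next to the ether oxygen, and compound 3, `CCOc1ccccc1OC(C)C(=O)Nc1ccc(OCC(=O)O)c(F)c1`, which carries an ethoxy group on the phenyl ring. For compound 2 in this assay the entry reads "not determined" (no result reported). Within the data shown here, for compound 3 in this assay the entry likewise reads "not determined" (no result reported), so the value of compound 1 is the only number available and no step between measured compounds can be stated.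

The compound to be measured is compound 4, `CC(Oc1cccc(C(C)(C)C)c1)C(=O)Nc1ccc(OCC(=O)O)c(F)c1`. It differs from compound 1 by a single change: tert-butyl in place of hydrogen on an aromatic carbon. Four carbon atoms are added without any new donor, acceptor or charge, and no ring is formed.

Among the measured compounds shown here, with no measured step to lean on, the expectation rests on the nature of the change alone. A step from compound 1 to compound 4 of a number 1.68 log units higher from compound 1 to compound 4 (beyond the scatter) is expected, clearly beyond the scatter and upward. Compound 4 is therefore estimated at 1.5, within a range from 0.8 to 2.2.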

Compound 4, distribution coefficient: 0.63
Estimate against measurement, compound 4: 0.87 log units above, and the stated range ends above it.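

Putting tert-butyl in place of hydrogen on an aromatic carbon, on a six-membered aromatic ring of carbon only and meta to a large group, gives a number 0.81 log units higher from compound 1 to compound 4 (beyond the scatter) in this assay. Among these compounds, this is the first step that can be read as a measured difference, as the earlier compounds offered a single number and nothing to set it against. It shows that this one change, with no new donor, acceptor or charge, is enough to carry the reading clearly past ordinary measurement noise, though the step remains modest, and it takes the value from -0.18 for compound 1 to 0.63 for compound 4, while nothing measured here accounts for the size of the step.

Going by these compounds, one substitution at one position cannot show how the reading depends on the size or nature of the group, so it remains open whether a methyl, a hydroxyl or an amine in place of the same hydrogen would shift it less, more or the other way. On these data alone, it is equally open whether tert-butyl on a different carbon of that ring would give a step of similar size.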